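A few compounds are considered here, and "the series" means these few. Any claim that something is new, unique, unknown or untested is made for them only; others in the source may bear on it.

Working notes on the series.

Two compounds carry numbers in a functional assay on MCF7 cells (Homo sapiens) for inhibition, read by resazurin assay, with a stated time of 72 h; on this read-out lower numbers stand for stronger inhibition and higher numbers for weaker inhibition. Compound 1 `C=CC1C(=O)N(c2cc(OC)c(OC)c(OC)c2)C1c1ccc(OC)cc1` gives 17 nM. Compound 2 `COc1cc(N2C(=O)C(Oc3ccccc3)C2c2ccc(SC)cc2)cc(OC)c1OC` gives 152 nM, the higher of the two numbers, and the gap to compound 1 lies beyond the scatter. Among the measured compounds shown here, no pair of measured compounds differs in a single place, so no measured step is available; compound 2 and compound 1 differ at more than one position and their two values show only that compound 1 sits lower.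

Compound 3 `COc1ccc(C2C(Oc3ccccc3)C(=O)N2c2cc(OC)c(OC)c(OC)c2)cc1` is not yet measured. It differs from compound 2 by methoxy in place of methylsulfanyl on an aromatic carbon. The same methoxy group sits at that position in compound 1, which is the only hint the data give. From that, the step from compound 2 to compound 3 is expected to be a 1.9-fold lower number from compound 2 to compound 3 (0.28 log units; within the scatter), toward a lower number, though it may fall within the scatter. Compound 3 is therefore estimated at 80 nM, within a range of 25 nM to 300 nM.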

Compound 3, half-maximal inhibitory concentration: 23 nM
Estimate against measurement, compound 3: 3.5-fold (0.54 log units) above; measured number below the stated range.
By their numbers in this assay, from the lowest: compounds 1 and 3 (each within the scatter of the next); then compound 2.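

In this assay, methoxy in place of methylsulfanyl on an aromatic carbon gives a 6.6-fold lower number from compound 2 to compound 3 (0.82 log units; beyond the scatter) with phenoxy held constant on the saturated ring carbon, so this aromatic position now has a measured single-place step that lies beyond the scatter. Phenoxy in place of vinyl on a saturated ring carbon gives a 1.4-fold higher number from compound 1 to compound 3 (0.13 log units; within the scatter) with 4-methoxyphenyl held constant, so in this setting the read-out does not separate these two groups. No available evidence bears on the reason for either step.

On these data alone, it remains open whether the step from 4-(methylsulfanyl)phenyl to 4-methoxyphenyl would be of similar size with vinyl on the saturated ring carbon. As far as these compounds go, how an amine, a carboxylic acid or a longer chain such as ethoxy would read at the aromatic position is also open.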